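This account rests on a few compounds, and the source may have more. Where it says the series, first, only, none or still open, it means among the compounds named here.

Measured so far in an ADME assay on L02 cells (Homo sapiens) for inhibition, read by MTT assay, with a stated time of 48 h, tested at 100 uM; on this read-out higher numbers stand for more inhibition at the one concentration tested (going by the name of the read-out) and lower numbers for less inhibition:

compound 1 `Cc1sc(-c2nsc(=O)o2)cc1[N+](=O)[O-]` gives 53.8%
compound 2 `O=c1nc(-c2ccc([N+](=O)[O-])cc2Cl)ss1` gives 28.6%
compound 3 `Cc1ccc(-c2nsc(=O)o2)s1` gives 25.1%

Compound 1 and compound 2 carry different cores; the difference between the two cores is not broken down here. Compound 3 and compound 1 differ in one place: hydrogen in place of nitro on an aromatic carbon. This step gives a number 28.7 percentage points lower from compound 1 to compound 3 (beyond the scatter). Compound 2 and compound 3 lie within the scatter of each other, while compound 2 stands beyond the scatter from compound 1.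

Compound 4 `O=c1nc(-c2ccccc2Cl)ss1` is not yet measured in this assay. It differs from compound 2 by hydrogen in place of nitro on an aromatic carbon. This is the same kind of change as that from compound 1 to compound 3, not the same change: in compound 3 the hydrogen enters on an aromatic carbon of a five-membered aromatic ring with 1 sulfur, next to the ring atom that bears a methyl group, two ring bonds from the ring sulfur and two ring bonds from the ring atom that bears a group of 6 heavy atoms; in compound 4 it enters on an aromatic carbon of a six-membered aromatic ring of carbon only, meta to a chloro group and para to a group of 6 heavy atoms.

Going by the values given here, only one measured step of this kind exists, a number 28.7 percentage points lower from compound 1 to compound 3 (beyond the scatter), so the expectation rests on that step alone, on a different core. A step in the same direction is expected for compound 4, smaller than the earlier one because compound 2 already starts at 28.6%: the expected step is a number 13.6 percentage points lower from compound 2 to compound 4 (beyond the scatter). Compound 4 is therefore estimated to give 15% in this assay, with an expected range from 2% to 32%.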

Compound 4, a percentage reported as inhibition, at one concentration (the size of the read-out at that concentration, not a potency): 40.1%
For compound 4 the middle estimate is 25.1 percentage points below the measured one; the measured number lies above the stated range.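

In this assay, putting hydrogen in place of nitro gives a number 11.5 percentage points higher from compound 2 to compound 4 (beyond the scatter), so the step seen on the core of compound 1 does not carry over to the core of compound 2, and even its direction is reversed: the same change on two cores in this assay, a number 28.7 percentage points lower (beyond the scatter) from compound 1 to compound 3 and a number 11.5 percentage points higher (beyond the scatter) from compound 2 to compound 4, 40.2 percentage points apart, beyond the scatter of two such steps

For this series, then, a nitro-to-hydrogen step measured on one core is no safe guide to the same change on another, and any estimate for a further core should not lean on a single earlier step. These two pairs do not show what sets the direction, since they differ at once in the core, in the ring that carries the nitro group and in the neighbouring substituents, and two steps at a single concentration give no rule for the series.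

Open, on these data alone, is how an amine or a carboxylic acid in the place of the nitro group would read on either core, and whether such groups would follow the step of the core they sit on. Also open, as far as these compounds go, is what part the chloro group of compound 2 and compound 4 plays in their step, as it stays unchanged in that pair.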